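This account rests on a few compounds, and the source may have more. Where it says the series, first, only, none or still open, it means among the compounds named here.

Measured so far:
- compound 1, `Nc1c(C(=O)NC2CCCC2)oc2nc(-c3ccccc3)cc(C(F)(F)F)c12`: 32400 nM
- compound 2, `Nc1c(C(=O)N/N=C/c2ccccc2)oc2nc(-c3cccs3)cc(C(F)(F)F)c12`: 9900 nM

Both compounds were read in a functional assay on HepG2 cells (Homo sapiens) for antiproliferative activity, read by MTT assay; on this read-out higher numbers stand for weaker inhibition and lower numbers for stronger inhibition. In this assay compound 1 gives 32400 nM and compound 2 gives 9900 nM. Compound 2 holds the lowest of the two numbers; the gap to compound 1 lies beyond the scatter. The two structures differ in more than one place, so nothing is taken from that pair beyond the two values themselves.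

The next compound is compound 3, `CCCNC(=O)c1oc2nc(-c3cccs3)cc(C(F)(F)F)c2c1N`. It differs from compound 2 as follows:

a group of 3 heavy atoms (3 carbon; no ring) in place of a group of 8 heavy atoms (7 carbon, 1 nitrogen; one six-membered aromatic ring of carbon only), on an amide-type nitrogen

Going by the values given here, no single-change step between measured compounds is available as a guide. Compound 1, the other amide in the set, sits well above compound 2, so a shift toward the higher, weaker end is expected, and the step of a 2.5-fold higher number from compound 2 to compound 3 (0.40 log units; beyond the scatter) is estimated to exceed the scatter. For compound 3 the estimate in this assay is 25000 nM, with a range from 8000 nM to 80000 nM.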

Compound 3, half-maximal inhibitory concentration: 17200 nM
For compound 3 the middle estimate is 1.5-fold (0.16 log units) above the measured one; low and high end bracket the measured number.
By their numbers in this assay, from the lowest: compounds 2, 3 and 1 (each within the scatter of the next, the first and the last beyond it).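

Going by these compounds alone, the first single-place comparison, read in this assay, concerns the amide-type nitrogen: propyl in place of the 8-heavy-atom group gives a 1.7-fold higher number from compound 2 to compound 3 (0.24 log units; within the scatter) and so leaves the two compounds indistinguishable. On this pair, the six-membered aromatic ring of carbon only and the double bond outside aromatic rings can both leave this position with no change beyond the scatter, so neither is required to keep the number at this level. No measured evidence bears on the reason for this result.

Still open, as far as these compounds go, is whether a longer chain such as hexyl, or a chain ending in an amine or a carboxylic acid, on the same nitrogen would move the number beyond the scatter. From the compounds shown here alone, this reading also rests on a single pair, so whether it holds with other groups elsewhere on the shared core remains open.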